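Swapping the Piperazine of Compound 1 for a Pyridyl Sulfide

A few compounds are considered here, and "the series" means these few. Any claim that something is new, unique, unknown or untested is made for them only; others in the source may bear on it.

For the measured compounds named here, compound 1 `FC(F)(F)c1ccc(CSc2nc(N3CCNCC3)cc(C(F)(F)F)n2)cc1` is one of two compounds measured in a functional assay on PC-3 cells (Homo sapiens) for inhibition, read by MTT assay, with a stated time of 72 h (a higher number here means a weaker inhibitor, a lower number a stronger inhibitor), where compound 1 gives 15900 nM. Going by the values given here, this is the lower of the two numbers: compound 2 `FC(F)(F)c1ccc(CSc2nc(N3CCN(c4ccccc4)CC3)cc(C(F)(F)F)n2)cc1` gives 42700 nM, and the single step measured so far, a 2.7-fold higher number from compound 1 to compound 2 (0.43 log units; beyond the scatter), shows that placing phenyl on the amine nitrogen of the ring weakened inhibition to a modest degree.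

Compound 3 `FC(F)(F)c1ccc(CSc2nc(Sc3ccccn3)cc(C(F)(F)F)n2)cc1` has not yet been measured. It differs from compound 1 by (pyridin-2-yl)sulfanyl in place of piperazin-1-yl on an aromatic carbon. Among the compounds with values here, the only measured step touches the same region of the core, since in compound 2 the piperazin-1-yl ring was extended rather than replaced, but it is the closest guide available. That step was modest and went toward a weaker inhibitor, and the present change also removes the hydrogen-bond donor that compound 1 carries there. A step of similar size in the same direction is therefore expected, a 2.2-fold higher number from compound 1 to compound 3 (0.34 log units; beyond the scatter), although the evidence for this is thin. Compound 3 is estimated at 35000 nM, with a range from 12000 nM to 100000 nM.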

Compound 3, half-maximal inhibitory concentration: 25200 nM
For compound 3 the middle estimate is 1.4-fold (0.14 log units) above the measured one; low and high end bracket the measured number.
By their numbers in this assay, from the lowest: compounds 1, 3 and 2 (each within the scatter of the next, the first and the last beyond it).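

In this assay, exchanging the whole piperazin-1-yl ring for (pyridin-2-yl)sulfanyl gives a 1.6-fold higher number from compound 1 to compound 3 (0.20 log units; within the scatter), so this far larger change cannot be told apart from compound 1 in this measurement. The earlier step only extended the piperazin-1-yl ring, whereas here that ring and its hydrogen-bond donor leave altogether and an aromatic ring joined through sulfur enters, which shows that the position accepts a very different group without a clear shift in the number. Nothing measured here explains why these two groups read alike.

From the compounds shown here alone, it remains open whether the sulfur link or the pyridine ring matters more for this reading, and a phenylsulfanyl group, a pyridin-2-yloxy group or a morpholine ring at the same carbon would help to separate those parts. Going by these compounds, it is also open whether any group at this position can take the number beyond the scatter toward a stronger inhibitor in this assay, for instance a small open-chain amine such as dimethylamino, or a piperazine carrying a short carboxylic acid chain.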